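The compounds below may be only part of what the source reports. "The series", "measured", "known", "first", "only" and "open" are said of these compounds alone.

In a functional assay, read by spectrophotometry, with a stated time of 2 h, tested at 0.5 mg/mL (a higher number here means a stronger effect of the compound at the concentration tested, a lower number a weaker effect), compound 2 `CC(C)[C@@H]1CC[C@@H](C)C[C@@]12N(C)C(=O)[C@@H]1[C@H]3C(=O)N(C)C(=O)[C@H]3ON12` gives 39.2%, the higher of the two numbers recorded, while compound 1 `CC(C)[C@@H]1CC[C@@H](C)C[C@@]12N(C)C(=O)[C@@H]1[C@H]3C(=O)NC(=O)[C@H]3ON12` gives 23.5%. For the measured compounds named here, the single measured step, a number 15.7 percentage points higher from compound 1 to compound 2 (beyond the scatter), concerns a methyl entering where a hydrogen stood. Compound 3 `CC(C)[C@@H]1CC[C@@H](C)C[C@@]12N(C)C(=O)[C@@H]1[C@H]3C(=O)N(c4ccccc4)C(=O)[C@H]3ON12` differs from compound 2 by phenyl in place of methyl on an amide-type nitrogen in a ring. Going by the values given here, no measured step covers a phenyl entering at that nitrogen, so neither size nor direction can be read from the data, and the expected step is a number 0.8 percentage points higher from compound 2 to compound 3 (within the scatter), not beyond the scatter. Compound 3 is therefore estimated at 40%, within 20% to 60%.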

Compound 3, a percentage reported as activity, at one concentration (the size of the read-out at that concentration, not a potency): 14.7%
Estimate against measurement, compound 3: 25.3 percentage points above, and the stated range ends above it.
By their numbers in this assay, from the lowest: compounds 3 and 1 (each within the scatter of the next); then compound 2.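

In this assay the amide-type nitrogen in the ring does not simply reward any group placed on it: phenyl in place of methyl gives a number 24.5 percentage points lower from compound 2 to compound 3 (beyond the scatter) and so removes what methyl had gained. Set against the amide hydrogen, phenyl gives a number 8.8 percentage points lower from compound 1 to compound 3 (within the scatter) and so brings no gain over the unsubstituted nitrogen. No evidence at hand bears on this result. The compounds shown leave open whether an ethyl group or a longer chain on this nitrogen would read like methyl or like phenyl, and what a benzyl group or an amine on the phenyl ring would give.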